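A few compounds are considered here, and "the series" means these few. Any claim that something is new, unique, unknown or untested is made for them only; others in the source may bear on it.

Compound 1 `N=C(N)NCCC[C@H](NC(=O)CN(c1nc(Cl)nc2[nH]cnc12)C1CC1)C(=O)O` gives 51% in a functional assay on the whole organism (Tail, strain ICR) with Mus musculus as the target, in the tail flick test, with a stated time of 60 min, at a dose of 25 umol/kg by the oral route; a lower number here means a weaker effect, a higher number a stronger effect of the compound at the dose given.
Compound 2 `CC[C@H](C)[C@H](NC(=O)CN(c1nc(Cl)nc2[nH]cnc12)C1CC1)C(=O)O` gives 36% in this assay.
Compound 3 `O=C(CN(c1nc(Cl)nc2[nH]cnc12)C1CC1)N[C@@H](CO)C(=O)O` gives 39.8% in this assay.

Compound 3 stands second highest of these three numbers. Its nearest neighbour is compound 2, with a number 3.8 percentage points higher from compound 2 to compound 3 (within the scatter), so the two cannot be told apart. The gap to compound 1 is larger, a number 11.2 percentage points lower from compound 1 to compound 3 (beyond the scatter), and lies beyond the scatter.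

Compound 4 `NC(=O)C[C@H](NC(=O)CN(c1nc(Cl)nc2[nH]cnc12)C1CC1)C(=O)O` differs from compound 3 in one place: carbamoyl in place of hydroxy on a saturated chain carbon, two bonds along the chain from an amide-type nitrogen and a carbonyl carbon. Among the compounds with values here, two measured steps touch the same place. From compound 1 to compound 3 an oxygen atom replaced a group of six heavy atoms, and the number fell; from compound 2 to compound 3 hydroxymethyl replaced sec-butyl, and the number stayed within the scatter. Carbamoyl is larger than hydroxy but smaller than the group that leaves from compound 1 to compound 3. For compound 4 a step of modest size at most is expected in this assay, and most likely one that stays within the scatter.

Compound 4 is therefore estimated at 42%, within 30% to 55%, which means an expected step of a number 2.2 percentage points higher from compound 3 to compound 4 (within the scatter).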

Compound 4, a percentage reported as activity, at one dose (the size of the read-out at that dose, not a potency): 43.1%
The estimate for compound 4 lay 1.1 percentage points below the measured number, within the range that was stated.
By their numbers in this assay, from the lowest: compounds 2, 3, 4 and 1 (each within the scatter of the next, the first and the last beyond it).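

In this assay, carbamoyl in place of hydroxy on this saturated chain carbon cannot be told from no change (a number 3.3 percentage points higher from compound 3 to compound 4 (within the scatter)), and the same holds for carbamoylmethyl in place of sec-butyl (a number 7.1 percentage points higher from compound 2 to compound 4 (within the scatter)). Within the data shown here, compound 2 and compound 3 each lie beyond the scatter from compound 1, but compound 4 does not (a number 7.9 percentage points lower from compound 1 to compound 4 (within the scatter)), so it is the one compound here that overlaps all the others and sits with neither end of the series.

The compounds shown leave open whether a carboxylic acid or an amine at this place, or a longer chain ending in carbamoyl, would read closer to compound 1 or to compound 2. They also leave open how these compounds compare in potency, as each reading comes from one dose at one time.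

Nothing available gives a reason for these numbers.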